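The source may hold more compounds than are shown below. What is called first, only, known or untested is meant among the compounds shown, and "the series" means these compounds.

Compound 2, `Cc1nc(Cn2nc3ccc(-c4ccc(Oc5ccc(Cl)cc5)cc4)cn3c2=O)no1`, is the compound with the higher of the two numbers recorded in an ADME assay on microsomes (Canis lupus familiaris) for metabolic stability; a higher number here means that the compound lasts longer, a lower number that the compound disappears faster; in that assay compound 2 gives 5.9 h. Going by the values given here, the only other measured compound, compound 1, `Cc1noc(Cn2nc3ccc(-c4ccc(Oc5ccc(F)cc5)cc4)cn3c2=O)n1`, gives 3.62 h in this assay, and the gap between the two values lies within the scatter of repeated measurements, so the two compounds cannot be ranked against each other.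

Compound 3, `Cc1nc(Cn2nc3ccc(-c4ccc(Oc5ccc(F)cc5)cc4)cn3c2=O)no1`, has not yet been measured. It differs from compound 2 in one place: fluoro in place of chloro on an aromatic carbon. Compound 3 shares its 4-fluorophenoxy group with compound 1 but not the rest of its core, so the values of compounds 1 and 2 show only that a fluoro-bearing and a chloro-bearing compound of this series sit close together in this assay.

Among the compounds with values here, no measured step isolates this change. Compound 3 is therefore expected to stay close to compound 2, with a step of a 1.3-fold lower number from compound 2 to compound 3 (0.12 log units; within the scatter) that would be no larger than the scatter. The half-life of compound 3 in this assay is estimated at 4.5 h, within a range of 2.5 h to 8 h.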

Compound 3, half-life: 2.78 h
Estimate against measurement, compound 3: 1.6-fold (0.21 log units) above; the range from low to high includes it.
By their numbers in this assay, from the lowest: compounds 3, 1 and 2 (each within the scatter of the next, the first and the last beyond it).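

In this assay, going by these compounds alone, fluoro in place of chloro on an aromatic carbon, para to a large group, gives a 2.1-fold lower number from compound 2 to compound 3 (0.33 log units; beyond the scatter); this single matched pair is the first to isolate the change, which the two earlier compounds could not do since they differ in more than one place. The second change, 5-methyl-1,2,4-oxadiazol-3-yl in place of 3-methyl-1,2,4-oxadiazol-5-yl on a saturated chain carbon bound to an aromatic nitrogen, gives a 1.3-fold lower number from compound 1 to compound 3 (0.11 log units; within the scatter), so with the 4-fluorophenoxy group held constant, this exchange cannot be told apart from the scatter. Nothing among the data shown accounts for the step at the halogen position.

The compounds shown leave open whether the step from chloro to fluoro carries over to compounds with the 3-methyl-1,2,4-oxadiazol-5-yl group, as compound 1 is the only one shown with that group and it bears fluoro. They also leave open how this assay would respond to a bromo, a methyl, a methoxy or a plain hydrogen on the same aromatic carbon.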